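Piperidine for diethylamine on the benzoxazole series

The source may report more compounds than this note shows. Statements on the series, on what has been measured and on what is new or still open speak of the compounds shown alone.

Measured compounds:
compound 1 `CCN(CC)CCCOc1ccc(-c2nc3ccc(Oc4ccc(F)cc4)cc3o2)cc1` gives 5.4%
compound 2 `Fc1ccc(Oc2ccc3nc(-c4ccc(OCCCN5CCCCC5)cc4)oc3c2)cc1` gives 30.3%
compound 3 `CCN(CC)CCCOc1ccc(-c2nc3ccc(Oc4cccc(C(F)(F)F)c4)cc3o2)cc1` gives 24.1%

All three numbers come from an assay on isolated protein for inhibition of advanced glycosylation end product-specific receptor (Homo sapiens), read by FRET, with stated times of 30 min and 1 h, tested at 4 uM; on this read-out higher numbers stand for more inhibition at the one concentration tested (going by the name of the read-out) and lower numbers for less inhibition. Compound 1 and compound 2 differ by piperidin-1-yl in place of diethylamino on a saturated chain carbon, three bonds along the chain from an oxygen on an aromatic ring, and the step is a number 24.9 percentage points higher from compound 1 to compound 2 (beyond the scatter). Compound 1 and compound 3 differ by 3-(trifluoromethyl)phenyl in place of 4-fluorophenyl on an oxygen on an aromatic ring, with a step of a number 18.7 percentage points higher from compound 1 to compound 3 (beyond the scatter). No step is shown between compound 2 and compound 3; their two values sit within the scatter of each other.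

Compound 4 `FC(F)(F)c1cccc(Oc2ccc3nc(-c4ccc(OCCCN5CCCCC5)cc4)oc3c2)c1` is not yet measured in this assay. It differs from compound 3 by piperidin-1-yl in place of diethylamino on a saturated chain carbon, three bonds along the chain from an oxygen on an aromatic ring, the same change as that from compound 1 to compound 2, made at the same place on the chain. On these data alone, the expectation rests on compound 1 and compound 2, whose step is a number 24.9 percentage points higher from compound 1 to compound 2 (beyond the scatter); whether the same step carries over onto the core of compound 3 is untested, and single-concentration inhibition values need not add.

Compound 4 is expected to give about 45% in this assay. That estimate for compound 4 means a step of a number 20.9 percentage points higher from compound 3 to compound 4 (beyond the scatter). The expected range for compound 4 runs from 25% to 65%.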

Compound 4, a percentage reported as inhibition, at one concentration (the size of the read-out at that concentration, not a potency): 42.7%
The estimate for compound 4 lay 2.3 percentage points above the measured number, and the stated range covers the measured number.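

In this assay the piperidin-1-yl for diethylamino change carries over onto the core of compound 3, with a number 18.6 percentage points higher from compound 3 to compound 4 (beyond the scatter), and its two readings agree: the same change on two cores in this assay, a number 24.9 percentage points higher (beyond the scatter) from compound 1 to compound 2 and a number 18.6 percentage points higher (beyond the scatter) from compound 3 to compound 4, 6.3 percentage points apart, within the scatter of two such steps. The 3-(trifluoromethyl)phenyl for 4-fluorophenyl change also carries over, with a number 12.4 percentage points higher from compound 2 to compound 4 (beyond the scatter), and again its two readings agree: the same change on two cores in this assay, a number 18.7 percentage points higher (beyond the scatter) from compound 1 to compound 3 and a number 12.4 percentage points higher (beyond the scatter) from compound 2 to compound 4, 6.3 percentage points apart, within the scatter of two such steps. Across these four compounds the two changes therefore behave as roughly additive, but this rests on a single square of compounds and on inhibition at one concentration, and it shows neither a potency nor why the steps carry over.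

On these data alone, whether the step holds for another amine, such as pyrrolidin-1-yl or morpholin-4-yl, or for a chain longer than the 3-(piperidin-1-yl)propyl group remains open. Also open, as far as these compounds go, is whether the same additivity appears with other aryl groups on the oxygen, such as 4-chlorophenyl or 3-cyanophenyl.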